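From compound 1 to compound 4: one amine substituent exchanged

The source may report more compounds than this note shows. Statements on the series, on what has been measured and on what is new or still open speak of the compounds shown alone.

In an ADME assay on MT4 cells (Homo sapiens) for cytotoxicity, read by MTT assay, with a stated time of 5 days (on this read-out lower numbers stand for higher toxicity in this test and higher numbers for lower toxicity in this test), compound 1 `Cc1cc(/C=C/C#N)cc(C)c1Oc1cc(Nc2ccc(C#N)cc2)nc(NC2CC2)c1` gives 24800 nM, the highest of the three numbers and beyond the scatter of the other two. Compound 2 `Cc1cc(/C=C/C#N)cc(C)c1Oc1cc(NC2CC2)nc(Nc2ccc(C#N)cc2)n1` gives 3000 nM and compound 3 `Cc1cc(/C=C/C#N)cc(C)c1Oc1cc(NCCN2CCNCC2)nc(Nc2ccc(C#N)cc2)n1` gives 3650 nM. Compound 4 `Cc1cc(/C=C/C#N)cc(C)c1Oc1cc(NCC2CCCO2)nc(Nc2ccc(C#N)cc2)c1` carries (oxolan-2-yl)methyl in place of cyclopropyl on a nitrogen on an aromatic ring. Within the data shown here, the only measured exchange at such a nitrogen is a 1.2-fold higher number from compound 2 to compound 3 (0.09 log units; within the scatter), although compound 2 and compound 3 have a core different from that of compound 1. No change beyond the scatter is therefore expected, and the expected step is a 1.2-fold lower number from compound 1 to compound 4 (0.09 log units; within the scatter). For compound 4 the estimated value is 20000 nM, with an expected range of 7000 nM to 50000 nM.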

Compound 4, half-maximal cytotoxic concentration: 73600 nM
For compound 4 the middle estimate is 3.7-fold (0.57 log units) below the measured one, outside the stated range (above it).
By their numbers in this assay, from the lowest: compounds 2 and 3 (each within the scatter of the next); then compound 1; then compound 4.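

In this assay the exchange of cyclopropylamino for ((oxolan-2-yl)methyl)amino on the core of compound 1 gives a 3.0-fold higher number from compound 1 to compound 4 (0.47 log units; beyond the scatter) and points to lower toxicity in this test. Among these compounds, the earlier exchange at such a nitrogen gave a 1.2-fold higher number from compound 2 to compound 3 (0.09 log units; within the scatter) on a different core with a different entering group, so only this new step shows that a change at this nitrogen can move the read-out beyond the scatter. No measurement bearing on the origin of this step is available.
On these data alone, whether the step belongs to the ring oxygen or to the larger group stays open. A cyclopentylmethyl or an open-chain 2-methoxyethyl on this nitrogen would separate the two.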